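The source may hold more compounds than are shown below. What is called first, only, known or untested is meant among the compounds shown, and "the series" means these compounds.

Compound 1 `O=C(CN1CCN(c2ccc(Cl)cc2)CC1)N1CCN(c2ccc(Cl)cc2)CC1` gives 116000 nM
Compound 2 `Cc1ccc(N2CCN(C(=O)Cn3cnc([N+](=O)[O-])n3)CC2)cc1` gives 148000 nM
Compound 3 `O=C(Cn1cnc([N+](=O)[O-])n1)N1CCN(c2ccc(C(F)(F)F)cc2)CC1` gives 202000 nM

In an ADME assay on L6 cells (Rattus norvegicus) for cytotoxicity (on this read-out higher numbers stand for weaker inhibition and lower numbers for stronger inhibition), compound 2 gives 148000 nM and so sits within the scatter of both compound 1 and compound 3. Compound 4 `O=C(Cn1cnc([N+](=O)[O-])n1)N1CCN(C(=O)C2CC2)CC1` has not yet been measured. It differs from compound 2 in one place, with cyclopropylcarbonyl in place of 4-methylphenyl on an amine nitrogen in a ring. Among the measured compounds shown here, the only measured single-place step, trifluoromethyl in place of methyl on an aromatic carbon, shows a 1.4-fold higher number from compound 2 to compound 3 (0.14 log units; within the scatter) and stays small. For the measured compounds named here, no measured compound carries cyclopropylcarbonyl, so this guide is weak. The expected step is a 1.4-fold higher number from compound 2 to compound 4 (0.13 log units; within the scatter) and no clear shift in either direction is foreseen. Compound 4 is estimated at 200000 nM with 90000 nM to 400000 nM as the expected range.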

Compound 4, half-maximal inhibitory concentration: 156000 nM
Estimate against measurement, compound 4: 1.3-fold (0.11 log units) above; measured number inside the range.
By their numbers in this assay, from the lowest: compounds 1, 2, 4 and 3 (each within the scatter of the next).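

In this assay cyclopropylcarbonyl in place of 4-methylphenyl on an amine nitrogen in a ring gives a 1.1-fold higher number from compound 2 to compound 4 (0.02 log units; within the scatter) and so leaves the read-out effectively unchanged. The earlier step altered only a group on the aromatic ring, whereas this one removes that ring altogether, and the step still stays within the scatter. No available evidence accounts for this result. As far as these compounds go, it remains open whether a carboxylic acid, an amine or a longer chain on this nitrogen would move the number beyond the scatter.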